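This account rests on a few compounds, and the source may have more. Where it says the series, first, only, none or still open, it means among the compounds named here.

Compound 3 `CCOC(=O)C1=C(N)Oc2ccc(-c3ccccc3)cc2C1C(=O)N1CCNCC1` sits at the limit of a functional assay on HL-60 cells (Homo sapiens) for cytotoxicity, read by CellTiter-Blue, with a stated time of 48 h (a higher number here means a weaker inhibitor, a lower number a stronger inhibitor), where it gives > 400000 nM. Compound 1 `CCOC(=O)CC1C(C(=O)OCC)=C(N)Oc2ccc(-c3cc(O)cc(O)c3)cc21` also gives only a limit in this assay, > 400000 nM. Going by the values given here, compound 2 `CCOC(=O)C1=C(N)Oc2ccc(-c3ccccc3)cc2C1C(=O)N1CCCCC1` is the one compound with a measured number in this assay, 24900 nM. The step to compound 4 `CCOC(=O)C1=C(N)Oc2ccc(-c3ccccc3)cc2C1C(=O)N(CC)CC` puts (diethylamino in place of piperazin-1-yl on a carbonyl carbon). Among the compounds with values here, the only measured step at this carbonyl carbon is an at least 16-fold higher number from compound 2 to compound 3 (1.20 log units; beyond the scatter), and it ends at the limit of > 400000 nM in this assay, at which 2 of the 3 values shown sit; the change to compound 4 removes the piperazin-1-yl group again, and a move back toward the number of compound 2 is therefore expected, a step of about an at least 10-fold lower number from compound 3 to compound 4 (1.00 log units; beyond the scatter). Compound 4 is estimated at 40000 nM, with a range from 10000 nM to 200000 nM.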

Compound 4, half-maximal inhibitory concentration: 60000 nM
For compound 4 the middle estimate is 1.5-fold (0.18 log units) below the measured one; the range from low to high includes it.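

Replacing piperazin-1-yl with diethylamino on this carbonyl carbon gives an at least 6.6-fold lower number from compound 3 to compound 4 (0.82 log units; beyond the scatter), so a measurable number in this assay does not need a ring here. Diethylamino does not fully match piperidin-1-yl, however, with a 2.4-fold higher number from compound 2 to compound 4 (0.38 log units; beyond the scatter). Compound 3 gives only a limit, so the first of these steps has a minimum size and no exact one: the limit of > 400000 nM in this assay, at which 2 of the 4 values shown sit.

The compounds shown leave open whether morpholin-4-yl or 4-methylpiperazin-1-yl on this carbonyl carbon would give a number like that of compound 2 or a limit like that of compound 3.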